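This account rests on a few compounds, and the source may have more. Where it says the series, first, only, none or still open, it means among the compounds named here.

Notes on the series. Two compounds have numbers in a functional assay on MCF7 cells (Homo sapiens) for cytotoxicity, read by MTT assay, with a stated time of 2 days, tested at 0.1 uM; on this read-out lower numbers stand for a stronger effect and higher numbers for a weaker effect at the one concentration tested. Compound 1 `CC(=O)c1cc(-c2ccccc2)cc2cc(-c3ccc(F)cc3)[nH]c12` carries an acetyl group on the shared core, with a phenyl group and a 4-fluorophenyl group; in this assay compound 1 gives 98.5%. Compound 2 `CC(=O)c1cc(/C=C/c2ccc(F)cc2)cc2cc(-c3ccccc3)[nH]c12` keeps the acetyl group and the core, with the fluorophenyl moved onto a vinyl linker and a plain phenyl on the ring; in this assay compound 2 gives 89.7%. The two numbers lie within the usual scatter of each other, so nothing separates them, and the two structures differ in more than one place, so no single step can be read from them.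

Compound 3 `CC(=O)c1cc(/C=C/c2ccc(F)cc2)cc2cc(-c3ccc(F)cc3)[nH]c12` is not yet measured. It differs from compound 2 by fluoro in place of hydrogen on an aromatic carbon. Compound 1 already carries the 4-fluorophenyl group on the core and sits at 98.5%, so there is no sign that this group lowers the number. The step of a number 1.3 percentage points higher from compound 2 to compound 3 (within the scatter) is expected to stay within the scatter, with no clear direction. Compound 3 is expected to give 91% in this assay, with a range from 78% to 100%.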

Compound 3, a percentage reported as activity, at one concentration (the size of the read-out at that concentration, not a potency): 98.8%
Compound 3: middle estimate off by 7.8 percentage points, on the low side, within the range that was stated.
By their numbers in this assay, from the lowest: compounds 2, 1 and 3 (each within the scatter of the next).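

In this assay, within the data shown here, the change from phenyl to 4-fluorophenyl, fluoro in place of hydrogen on an aromatic carbon para to a large group, gives a number 9.1 percentage points higher from compound 2 to compound 3 (within the scatter) and is the first single-place reading at this position; with the 2-(4-fluorophenyl)ethenyl group held constant, fluoro has no effect here that can be separated from the scatter. The exchange of phenyl for 2-(4-fluorophenyl)ethenyl on an aromatic carbon, with the 4-fluorophenyl group held constant, gives a number 0.3 percentage points higher from compound 1 to compound 3 (within the scatter) and likewise cannot be told apart from the scatter at the one concentration tested. No supporting measurement accompanies either step, so the data shown offer no explanation for these readings.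

Still open, from the compounds shown here alone, is whether a group of a different kind at the para position of this phenyl ring, such as an amine or a carboxylic acid, would carry the number beyond the scatter. The compounds shown also leave open what happens when the acetyl group is replaced, for instance by a longer acyl chain, since all three carry it unchanged.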